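Shortening the fluorinated chain of compound 3

The compounds below may be only part of what the source reports. "The series", "measured", "known", "first", "only" and "open" are said of these compounds alone.

Among the compounds with values here, in a functional assay on the whole organism with Mus musculus as the target, in the writhing test (a lower number here means that less compound is needed, a higher number that more compound is needed for the effect), three compounds have values so far. Compound 1 (`CCCCSc1nsnc1C1CN2CCC1CC2`) gives 0.19 mg/kg and compound 2 (`C=CCCCCOc1nsnc1C1=CCCN(C)C1`) gives 0.9 mg/kg in this test. Compound 3 (`FC(F)(F)CCCCSc1nsnc1[C@@H]1CN2CCC[C@@H]1C2`) gives 0.07 mg/kg as the lowest of the three numbers, beyond the scatter from both of the others.

Compound 4 (`FC(F)(F)CCCSc1nsnc1[C@@H]1CN2CCC[C@@H]1C2`) has not yet been measured. The structural change is trifluoromethyl in place of 2,2,2-trifluoroethyl on a saturated chain carbon, three bonds along the chain from a sulfur on a saturated chain carbon, three bonds along the chain from a sulfur. Cut one bond further out, this reads as 4,4,4-trifluorobutyl to 3,3,3-trifluoropropyl.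

Within the data shown here, no pair of measured compounds isolates this change, so the series offers no direct precedent. The expectation rests only on compound 3 at 0.07 mg/kg and on the modest size of the change. The expected move is a 1.7-fold higher number from compound 3 to compound 4 (0.23 log units; within the scatter) toward a higher number, within the scatter. For compound 4 the estimated value is 0.12 mg/kg within an expected range of 0.04 mg/kg to 0.4 mg/kg by this estimate.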

Compound 4, dose for half-maximal effect: 0.35 mg/kg
Estimate against measurement, compound 4: 2.9-fold (0.46 log units) below; measured number inside the range.
By their numbers in this assay, from the lowest: compound 3; then compounds 1 and 4 (each within the scatter of the next); then compound 2.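

In this assay, within the data shown here, the change from 4,4,4-trifluorobutyl to 3,3,3-trifluoropropyl gives a 5.0-fold higher number from compound 3 to compound 4 (0.70 log units; beyond the scatter) and is the first step that differs in one place. This position is therefore not indifferent to the length of the fluorinated chain: with the shared core and the sulfur kept, the shortening alone moves the number beyond the scatter. No measurement at hand bears on the cause of this shift.

With a single step, the trend rests on these two chain lengths, and a longer chain such as 5,5,5-trifluoropentyl could either continue it or reverse it. Also open, on these data alone, is whether the same shortening carries the same weight on chains without fluorine, or with an ether oxygen in place of the sulfur on this core.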